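This account rests on a few compounds, and the source may have more. Where it says the series, first, only, none or still open, it means among the compounds named here.

Measured compounds:
compound 1, `COc1cc(NC(C)CCCNC(=O)Nc2cccc(F)c2)c2ncccc2c1`, 27000 nM
compound 2, `COc1cc(NC(C)CCCNC(=O)NNC(=O)Nc2ccc(Cl)cc2)c2ncccc2c1`, 48000 nM
compound 3, `COc1cc(NC(C)CCCNC(=O)Nc2cc(C(F)(F)F)cc(C(F)(F)F)c2)c2ncccc2c1`, 3900 nM

In a functional assay on SW-620 cells (Homo sapiens) for inhibition, read by MTT assay, with a stated time of 72 h (a higher number here means a weaker inhibitor, a lower number a stronger inhibitor), compound 1 gives the second highest of the three numbers. Its nearest neighbour is compound 2: the step of a 1.8-fold higher number from compound 1 to compound 2 (0.25 log units; within the scatter) lies within the scatter, so the two cannot be ordered. Going by the values given here, compound 3 stands furthest away, with a number that is markedly lower than that of compound 1, and that gap does lie beyond the scatter; no single-change step connects these two compounds, so only the two values themselves can be compared.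

The unmeasured compound 4, `COc1cc(NC(C)CCCNC(=O)Nc2cccc(C(F)(F)F)c2)c2ncccc2c1`, differs from compound 1 in one place: trifluoromethyl in place of fluoro on an aromatic carbon.

Among the compounds with values here, the only measured step with a single change, that from compound 1 to compound 2, alters a different part of the molecule and stays within the scatter, so it says little about this change. The comparison of compound 1 with compound 3, which carries two trifluoromethyl groups on the same ring, is more telling: a lower number by a clear margin. Compound 4 carries one such group, so a lower number than for compound 1 is expected, though of a smaller size than the whole gap to compound 3. The expected step is a 2.5-fold lower number from compound 1 to compound 4 (0.39 log units; beyond the scatter). For compound 4 the estimate is 11000 nM, between 4000 nM and 30000 nM.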

Compound 4, half-maximal inhibitory concentration: 22000 nM
Estimate against measurement, compound 4: 2.0-fold (0.30 log units) below; low and high end bracket the measured number.
By their numbers in this assay, from the lowest: compound 3; then compounds 4, 1 and 2 (each within the scatter of the next, the first and the last beyond it).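

In this assay the exchange of fluoro for trifluoromethyl on this aromatic carbon brings 4 heavy atoms in place of 1, yet a 1.2-fold lower number from compound 1 to compound 4 (0.09 log units; within the scatter) shows no change that can be read, so this position accepts either group with no measurable difference. Compound 3 now has a single-change partner, and the removal of one of its two trifluoromethyl groups gives a 5.6-fold higher number from compound 3 to compound 4 (0.75 log units; beyond the scatter), which ties its separation from the others to that second group, while the 3-(trifluoromethyl)phenyl group on the amide-type nitrogen in place of the ((4-chlorophenyl)carbamoyl)amino group gives a 2.2-fold lower number from compound 2 to compound 4 (0.34 log units; beyond the scatter), a modest step. Nothing at hand offers an explanation for these steps.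

As far as these compounds go, whether a nitrile, an amine or a carboxylic acid on this aromatic carbon would also leave the number where compound 1 and compound 4 stand remains open. From the compounds shown here alone, it is equally open whether a second fluoro on the ring would match the second trifluoromethyl group of compound 3, or whether that step belongs to trifluoromethyl alone.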